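Dropping the methoxy from compound 2

The source may hold more compounds than are shown below. What is called first, only, known or untested is meant among the compounds shown, and "the series" means these compounds.

Three chalcones built on closely related cores have been tested in a functional assay on MDA-MB-231 cells (Homo sapiens), read by fluorescence and BrdU incorporation, with a stated time of 48 h, tested at 10 uM; a lower number here means a stronger effect, a higher number a weaker effect of the compound at the concentration tested. Compound 1 `COc1cc(O)c(C(=O)/C=C/c2ccc(F)cc2)c(OC)c1` gives "not active" (no number reported) in this assay. Compound 3 `COc1cc(O)c(C(=O)/C=C/c2ccccc2SC)c(OC)c1` likewise gives "not active" (no number reported) in this assay. Compound 2 `COc1cccc(/C=C/C(=O)c2c(OC)cc(OC)cc2OC)c1` is the only one of the three to return a number: in this assay compound 2 gives 43%. Compound 2 therefore stands alone with a measured figure, and the two other entries carry no value against which it could be ranked.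

The next compound, compound 4 `COc1cc(OC)c(C(=O)/C=C/c2ccccc2)c(OC)c1`, differs from compound 2 in one place: hydrogen in place of methoxy on an aromatic carbon.

Among the compounds with values here, no two measured compounds differ in a single place, so there is no step of known size to lean on. Within the data shown here, the expectation is a step toward a weaker effect, of a size that may reach beyond the usual scatter, since compound 2 is the only anchor with a value of 43% and the two companions that gave no number sit on a different core. The estimate for compound 4 in this assay is 65%, with a range from 40% to 95%. The expected step is a number 22 percentage points higher from compound 2 to compound 4 (beyond the scatter).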

Compound 4, a percentage reported as activity, at one concentration (the size of the read-out at that concentration, not a potency): 37%
Compound 4: the middle estimate sits 28 percentage points above what was measured; measured number below the stated range.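

In this assay, within the data shown here, the change from 3-methoxyphenyl to phenyl gives a number 6 percentage points lower from compound 2 to compound 4 (within the scatter), the first step of known size on this core. At this position, on an aromatic carbon meta to a large group, the two compounds cannot be told apart at the concentration tested, so the read-out does not depend on the methoxy being present in this pair. The compounds shown offer no measured explanation for this outcome.

Going by these compounds, only methoxy and hydrogen have been compared at this position, so it remains open whether an amine, a carboxylic acid or a longer chain such as butoxy would give a different read-out here. On these data alone, it also remains open whether the same exchange would give a similar step on the core of compound 1.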